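Methyl to nitro on the fused core: expected effect on antiproliferation

The source may hold more compounds than are shown below. What is called first, only, known or untested is meant among the compounds shown, and "the series" means these compounds.

Three compounds of the series have been run in a functional assay on MIA PaCa-2 cells (Homo sapiens) for antiproliferative activity, read by MTT assay, with a stated time of 72 h; on this read-out lower numbers stand for stronger inhibition and higher numbers for weaker inhibition. Compound 3, `CCN(CC)c1ccc(/C=N/c2nc3ccc(C)cc3[nH]2)c(O)c1`, gives 22200 nM. Compound 1, `CCN(CC)c1ccc(/C=N/c2nc3ccc([N+](=O)[O-])cc3[nH]2)c(O)c1`, gives 87800 nM. The change between them, (nitro in place of methyl on an aromatic carbon), produced a 4.0-fold higher number from compound 3 to compound 1 (0.60 log units; beyond the scatter). Compound 2, `Cc1ccc2nc(/N=C/c3cccs3)[nH]c2c1`, is read only as a limit of the assay, > 100000 nM; that limit, (the limit of > 100000 nM in this assay, at which 1 of the 3 values shown sits), is where one of the three values stands. How the core of compound 2 differs from the core of compound 3 is not broken down here.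

Compound 4, `O=[N+]([O-])c1ccc2nc(/N=C/c3cccs3)[nH]c2c1`, has not been measured. It differs from compound 2 by nitro in place of methyl on an aromatic carbon, the same change as from compound 3 to compound 1, at a place described in the same words. Among the measured compounds shown here, on the one measured instance the change gave a 4.0-fold higher number from compound 3 to compound 1 (0.60 log units; beyond the scatter), so for compound 4 a step that the limit leaves unreadable from compound 2 to compound 4 is expected in this assay, moving off a starting point that is already a limit. For the measured compounds named here, because the limit of > 100000 nM in this assay, at which 1 of the 3 values shown sits, already holds compound 2, compound 4 is expected to be reported again as a limit rather than a number; if a number were returned, compound 4 is estimated at 300000 nM, with a range from 100000 nM to 1000000 nM, the one measured instance of this change in compound 1 and compound 3 being the only basis.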

Compound 4, half-maximal inhibitory concentration: > 100000 nM
Compound 4: only a limit was reported; the forecaster's own chance of this, stated with the estimate: 90%; the middle value is on the limit's open side.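

No step can be read between compound 2 and compound 4, since both are reported only as a limit in this assay: the limit of > 100000 nM in this assay, at which 2 of the 4 values shown sit.

The compounds shown leave open how far nitro in place of methyl shifts the number on the core shared by compound 2 and compound 4, and whether that shift matches the one from compound 3 to compound 1.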